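The source may report more compounds than this note shows. Statements on the series, on what has been measured and on what is new or still open speak of the compounds shown alone.

Measured compounds in a functional assay on SW-620 cells (Homo sapiens) for antiproliferative activity, read by MTT assay, with a stated time of 72 h; a higher number here means a weaker inhibitor, a lower number a stronger inhibitor:
Compound 1 `Cc1ccc(-c2cn(C/C=C3\OC(=O)C(OCc4ccccc4)=C3OCc3ccccc3)nn2)cc1` gives > 100000 nM, a limit of the assay rather than a number.
Compound 2 `O=C1O/C(=C\Cn2cc(-c3cc(F)cc(F)c3)nn2)C(OCc2ccccc2)=C1OCc1ccccc1` gives > 100000 nM, likewise only a limit.
Compound 3 `O=C1O[C@H]([C@@H](O)Cn2cc(-c3cccc(O)c3)nn2)C(OCc2ccccc2)=C1OCc1ccccc1` gives > 100000 nM, again only a limit.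

Compound 3 therefore stands at the limit, and so do the two other values shown; this is the limit of > 100000 nM in this assay, at which 3 of the 3 values shown sit. Within the data shown here, the single measured step, a step that the two limits leave unreadable from compound 1 to compound 2, is unreadable for the same reason. Compound 4 `COc1ccccc1-c1cn(C[C@H](O)[C@H]2OC(=O)C(OCc3ccccc3)=C2OCc2ccccc2)nn1` differs from compound 3 by 2-methoxyphenyl in place of 3-hydroxyphenyl on an aromatic carbon. No measured step bears on this change, and none of the shown values gives a number to anchor it. The expectation for compound 4 in this assay is thus a step of a number no higher from compound 3 to compound 4 (the limit leaves the size open), nothing readable beyond the scatter. Compound 4 is estimated at 100000 nM, within 30000 nM to 300000 nM, most likely reported again as a limit.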

Compound 4, half-maximal inhibitory concentration: > 100000 nM
Compound 4 gave a limit, no number; the forecaster's own chance of this, stated with the estimate: 80%; the middle value sits exactly at the limit.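

Compound 4 returns only a limit, so no step can be read between compound 3 and compound 4: the limit of > 100000 nM in this assay, at which 4 of the 4 values shown sit.

The compounds shown leave open how 2-methoxyphenyl and 3-hydroxyphenyl compare, and which structures would give a true number in this assay.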